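Compound 3: phenyl in place of tert-butyl

A few compounds are considered here, and "the series" means these few. Any claim that something is new, unique, unknown or untested is made for them only; others in the source may bear on it.

Measured so far: compound 1 `C[C@H](NC(=O)C(=O)Nc1ccccc1C(C)(C)C)C(=O)N[C@@H](CC(=O)O)C(=O)COC(=O)c1c(Cl)cccc1Cl` gives 143 nM in a functional assay on Jurkat cells (Homo sapiens) for inhibition; on this read-out higher numbers stand for weaker inhibition and lower numbers for stronger inhibition; compound 2 `C[C@H](NC(=O)C(=O)Nc1cc(C(C)(C)C)ccc1C(C)(C)C)C(=O)N[C@@H](CC(=O)O)C(=O)COC(=O)c1c(Cl)cccc1Cl` gives 1380 nM in this assay.

Compound 1 stands lowest of the two numbers. Among the measured compounds shown here, the only measured step, a 9.7-fold higher number from compound 1 to compound 2 (0.98 log units; beyond the scatter), concerns an added tert-butyl rather than the one exchanged here. Compound 3 `C[C@H](NC(=O)C(=O)Nc1ccccc1-c1ccccc1)C(=O)N[C@@H](CC(=O)O)C(=O)COC(=O)c1c(Cl)cccc1Cl` differs from compound 1 by phenyl in place of tert-butyl on an aromatic carbon. For the measured compounds named here, no measured step bears directly on this exchange, so the expectation rests on compound 1 alone and is wide. A step of a 1.7-fold higher number from compound 1 to compound 3 (0.24 log units; within the scatter) is expected, small and possibly within the scatter. Compound 3 is estimated at 250 nM, between 60 nM and 1000 nM.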

Compound 3, half-maximal inhibitory concentration: 390 nM
For compound 3 the middle estimate is 1.6-fold (0.19 log units) below the measured one, within the range that was stated.
By their numbers in this assay, from the lowest: compound 1; then compound 3; then compound 2.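

In this assay, among the compounds shown here, the group on this aromatic carbon itself changes for the first time: phenyl in place of tert-butyl gives a 2.7-fold higher number from compound 1 to compound 3 (0.44 log units; beyond the scatter). The position therefore accepts an aromatic ring with six carbon atoms, but compound 1 keeps the lower number, and the step is modest. Nothing available explains this difference.

The compounds shown leave open how a methyl, a cyclohexyl or an amine would read at this place. They also leave open whether a substituted phenyl would recover the number of compound 1.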